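The source may hold more compounds than are shown below. What is called first, only, known or untested is meant among the compounds shown, and "the series" means these compounds.

Series notes. For the measured compounds named here, the shared core is that of compound 1 `CCCCCCCCCCc1ccc(-c2noc(C3CCNC3)n2)cc1`, which in an assay on HeLa cells for inhibition of sphingosine-1-phosphate transporter SPNS2 (Mus musculus), read by LC-MS, tested at 2 uM (a higher number here means more inhibition at the concentration tested (going by the name of the read-out), a lower number less inhibition), gives 26%, the second highest of the three numbers measured so far. Compound 3 `CCCCCCCCCCc1ccc(-c2noc([C@@H](N)CCCN)n2)cc1` gives 40% in this assay, and compound 2 `CCCCCCCCCCc1ccc(-c2noc(CC[C@@H](N)C(=O)O)n2)cc1` gives 5%. The two measured steps that start from compound 1 move in opposite directions: a number 14 percentage points higher from compound 1 to compound 3 (beyond the scatter), and a number 21 percentage points lower from compound 1 to compound 2 (beyond the scatter); between the other two, a number 35 percentage points higher from compound 2 to compound 3 (beyond the scatter).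

Compound 4 `CCCCCCCCCCc1ccc(-c2noc(CC(O)CN3CCCCC3)n2)cc1` is the next member to be measured. Relative to compound 1 it changes in one place: 2-hydroxy-3-(piperidin-1-yl)propyl in place of pyrrolidin-3-yl on an aromatic carbon. Neither measured step installs a 2-hydroxy-3-(piperidin-1-yl)propyl group, so the direction of this step is not fixed by the data. Both measured steps from compound 1 were modest in size, and a step of similar, modest size in either direction is the reasonable expectation for this assay. On that basis compound 4 is estimated to give 30% in this assay, between 10% and 50%, which is expected to amount to a number 4 percentage points higher from compound 1 to compound 4 (within the scatter).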

Compound 4, a percentage reported as inhibition, at one concentration (the size of the read-out at that concentration, not a potency): 2%
Beside the measured number, compound 4's estimate is 28 percentage points above it, outside the stated range (below it).
By their numbers in this assay, from the lowest: compounds 4 and 2 (each within the scatter of the next); then compound 1; then compound 3.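

The 2-hydroxy-3-(piperidin-1-yl)propyl group does not hold the level of the smaller pyrrolidin-3-yl group (a number 24 percentage points lower from compound 1 to compound 4 (beyond the scatter)) and falls much further short of the 1,4-diaminobutyl group (a number 38 percentage points lower from compound 3 to compound 4 (beyond the scatter)), so a nitrogen-bearing group at this position is not enough on its own to keep the inhibition. A low number here also does not depend on a carboxylic acid: compound 4 has none, yet it is not separated from the 3-amino-3-carboxypropyl group of compound 2 (a number 3 percentage points lower from compound 2 to compound 4 (within the scatter)). Nothing available explains these differences.

The compounds shown do not separate the contribution of the hydroxyl from that of the piperidine ring. A 3-(piperidin-1-yl)propyl chain without the hydroxyl, or a primary amine at the end of the same chain, would address that question.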